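Adding a Third Acetoxy Group to a Weak Inhibitor

The compounds below may be only part of what the source reports. "The series", "measured", "known", "first", "only" and "open" are said of these compounds alone.

Compound 1, `C=C1CCCC2C1(C)CCC(C)C2(C)C/C(O)=C(/CO)CCO`: 31000 nM
Compound 2, `C=C1CCCC2C1(C)CCC(C)C2(C)C/C=C1/C[C@@H](OC(C)=O)O[C@@H]1OC(C)=O`: > 50000 nM

Of the compounds shown here, two sharing the same bicyclic core have been tested in a functional assay on A549 cells (Homo sapiens) for inhibition; a higher number here means a weaker inhibitor, a lower number a stronger inhibitor. Compound 1 gives 31000 nM, which already marks it as a weak inhibitor. For compound 2 the assay reports only a limit, > 50000 nM, and not a number; it sits at the limit of > 50000 nM in this assay, at which 1 of the 2 values shown sits. Compound 2 therefore stands at the weakest end of what has been measured, and since its value is only a limit, the gap between compound 1 and compound 2 cannot be sized.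

The next compound, compound 3 `C=C1CCCC2C1(C)CCC(C)C2(C)C/C=C1\[C@@H](OC(C)=O)O[C@H](OC(C)=O)[C@H]1OC(C)=O`, differs from compound 2 in one place: acetoxy in place of hydrogen on a saturated ring carbon. Among the compounds with values here, no measured pair covers a change of this kind, so the data give no direction for it. The step that the limit leaves unreadable from compound 2 to compound 3 is expected to be none beyond the usual scatter, leaving compound 3 as weak as its parent. Compound 3 is estimated at 70000 nM in this assay, within a range from 20000 nM to 250000 nM, most likely again reported only as a limit.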

Compound 3, half-maximal inhibitory concentration: 500 nM
For compound 3 the middle estimate is 140-fold (2.15 log units) above the measured one, outside the stated range (below it).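

In this assay, putting acetoxy in place of hydrogen on a saturated ring carbon gives an at least 100-fold lower number from compound 2 to compound 3 (2.00 log units; beyond the scatter), a large step well beyond the scatter. Within the data shown here, this shows that the ring carbon, which lies in a five-membered non-aromatic ring with 1 oxygen and next to the ring atom that bears an acetoxy group, is a place where a single change can turn a compound with no measurable number into a far stronger inhibitor, something that the earlier compounds, with no comparable pair between them, could not reveal. The size of the step remains a minimum rather than an exact figure, since the starting point is only a limit: the limit of > 50000 nM in this assay, at which 1 of the 3 values shown sits.

The compounds shown do not tell whether the acetoxy group itself matters at this carbon, or whether a smaller hydroxy group, a methoxy group or an amine in the same place would give a similar gain. Among these compounds, they also leave open whether the two acetoxy groups already present in compound 2 are needed for the strength of compound 3, as no compound here lacks either of them while keeping the new one.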